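A Trifluoromethyl Swap on a Potent Alpha-1D Agonist

The source may report more compounds than this note shows. Statements on the series, on what has been measured and on what is new or still open speak of the compounds shown alone.

Compound 1, `CSc1ccc(C)cc1NCC1=NCCN1`: 0.912 nM
Compound 2, `Cc1ccc(S(C)(=O)=O)c(NCC2=NCCN2)c1`: < 2000 nM (a limit)
Compound 3, `CS(=O)(=O)c1c(F)cccc1NCC1=NCCN1`: < 100000 nM (a limit)

Among the compounds with values here, in a functional assay for agonist activity at Alpha-1D adrenergic receptor (Homo sapiens) (a higher number here means that more compound is needed for the effect, a lower number that less compound is needed), compound 1 gives 0.912 nM, and this is the only plain number among the three measured compounds. For compound 2 the result is a limit of this assay rather than a number, < 2000 nM. For compound 3 the result is likewise a limit, < 100000 nM. Within the data shown here, the one step between compounds that differ in a single place, a step that the limit leaves unreadable from compound 1 to compound 2, therefore cannot be sized, since one end of it sits at the limit of < 2000 nM in this assay, at which 1 of the 3 values shown sits. The other measured compound sits at the limit of < 100000 nM in this assay, at which 1 of the 3 values shown sits, which equally yields no readable step.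

Compound 4, `CSc1ccc(C(F)(F)F)cc1NCC1=NCCN1`, is not yet measured. Compared with compound 1 the change is trifluoromethyl in place of methyl on an aromatic carbon. No measured step alters this group, so nothing among the shown values points in a direction for the change. The expectation rests only on compound 1 at 0.912 nM and on the modest size of the change; the step of a 2.2-fold higher number from compound 1 to compound 4 (0.34 log units; beyond the scatter) is expected to lie close to the usual scatter, with no strong shift either way. Compound 4 is therefore estimated at 2 nM, in a range from 0.5 nM to 10 nM.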

Compound 4, half-maximal effective concentration: 43.7 nM
Compound 4: middle estimate off by 22-fold (1.34 log units), on the low side, outside the stated range (above it).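

Within the data shown here, replacing methyl with trifluoromethyl on the aromatic carbon para to the methylsulfanyl group gives a 48-fold higher number from compound 1 to compound 4 (1.68 log units; beyond the scatter) in this assay, the first step in this set that can be sized, as the others cannot be read. This position is therefore not indifferent to what sits on it: changing this one group, while the methylsulfanyl group and the rest of the core of compound 1 stay the same, is enough to require clearly more compound for the effect, although compound 4 still gives a plain number, 43.7 nM. No measurement shown speaks to what lies behind this step.

From the compounds shown here alone, whether a single chlorine, an ethyl chain or a methoxy group at this position would land nearer to compound 1 or nearer to compound 4 remains open, as two groups alone cannot show how the result varies from one group to another. Also open, going by these compounds, is how the same swap behaves alongside methylsulfonyl in place of methylsulfanyl, the group carried by compound 2, whose result is a limit, < 2000 nM.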